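Chloro step from compound 3 to compound 4

The source may hold more compounds than are shown below. What is called first, only, known or untested is meant among the compounds shown, and "the series" means these compounds.

Values in a functional assay on HT-29 cells (Homo sapiens) for antiproliferative activity, read by sulforhodamine B assay, with a stated time of 72 h; on this read-out lower numbers stand for stronger inhibition and higher numbers for weaker inhibition:
- compound 1 `O=C(Cn1nc(-c2ccccc2)c2ccccc2c1=O)Nc1ccccc1`: 99000 nM
- compound 2 `O=C(Cn1nc(-c2ccccc2)c2ccccc2c1=O)Nc1cccc(C(F)(F)F)c1`: 41200 nM
- compound 3 `O=C(Cn1nc(Cc2ccccc2)c2ccccc2c1=O)Nc1ccccc1`: 95400 nM

Benzyl in place of phenyl gives a 1.0-fold lower number from compound 1 to compound 3 (0.02 log units; within the scatter). Compound 3 therefore stands level with compound 1, and its number lies above that of compound 2.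

Compound 4 `O=C(Cn1nc(Cc2ccccc2)c2ccccc2c1=O)Nc1cccc(Cl)c1` carries one change: chloro in place of hydrogen on an aromatic carbon. For the measured compounds named here, no chloro compound has been measured. The closest measured step is trifluoromethyl in place of hydrogen on an aromatic carbon, a 2.4-fold lower number from compound 1 to compound 2 (0.38 log units; beyond the scatter), a modest one. A modest step to a lower number is therefore expected in this assay. The expected step is a 1.9-fold lower number from compound 3 to compound 4 (0.28 log units; within the scatter). Compound 4 is estimated at 50000 nM, with an expected range of 24000 nM to 100000 nM.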

Compound 4, half-maximal inhibitory concentration: 3680 nM
Estimate against measurement, compound 4: 14-fold (1.13 log units) above; measured number below the stated range.
By their numbers in this assay, from the lowest: compound 4; then compound 2; then compounds 3 and 1 (each within the scatter of the next).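

In this assay, for the compounds shown here, the anilino ring responds to substitution far more strongly than the earlier compounds showed: chloro gives a 26-fold lower number from compound 3 to compound 4 (1.41 log units; beyond the scatter) on the benzyl compounds, whereas trifluoromethyl gave a 2.4-fold lower number from compound 1 to compound 2 (0.38 log units; beyond the scatter) on the phenyl compounds. These steps sit on different cores, so the two groups cannot be ranked directly. Nothing available explains the size of the chloro step.

From the compounds shown here alone, whether the chloro gain carries over to the phenyl compounds stays open. So does whether a methoxy group or an amine on the same carbon would behave like chloro.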